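The source may report more compounds than this note shows. Statements on the series, on what has been measured and on what is new or still open speak of the compounds shown alone.

Cytotoxicity in a functional assay on BGC-823 cells (Homo sapiens) for cytotoxicity, read by MTT assay (on this read-out lower numbers stand for stronger inhibition and higher numbers for weaker inhibition), is followed across a shared core. Compound 1 `Cc1nc(Nc2ccc(Cl)c(Cl)c2)sc1C(=O)/C=C/c1ccccc1` gives 10600 nM in this assay. For compound 2 `Cc1nc(Nc2cccc(Cl)c2)sc1C(=O)/C=C/c1ccc(Cl)cc1` only a limit is recorded in this assay, > 25000 nM, so compound 2 stands at the limit of > 25000 nM in this assay, at which 1 of the 2 values shown sits. Compound 3 `Cc1nc(Nc2ccc(Cl)c(Cl)c2)sc1C(=O)/C=C/c1ccc(Cl)cc1` carries chloro in place of hydrogen on an aromatic carbon, that is, chloro in place of hydrogen on an aromatic carbon. For the measured compounds named here, no measured step pairs compound 2 with any other compound, and with compound 2 at a limit no step in this assay beyond the scatter is expected in either direction. Compound 3 is expected near 18000 nM, within 6000 nM to 50000 nM. That estimate amounts to a step of an at least 1.3-fold lower number from compound 2 to compound 3 (0.14 log units; that floor lies within the scatter).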

Compound 3, half-maximal inhibitory concentration: 22700 nM
For compound 3 the middle estimate is 1.3-fold (0.10 log units) below the measured one, within the range that was stated.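

In this assay the change from 3-chlorophenyl to 3,4-dichlorophenyl reads only as an at least 1.1-fold lower number from compound 2 to compound 3 (0.04 log units; that floor lies within the scatter) and gives no size for this position. On these data alone, that reading stays open-ended, since the value of compound 2 is a limit: the limit of > 25000 nM in this assay, at which 1 of the 3 values shown sits. Chloro in place of hydrogen on a different aromatic carbon gives a 2.1-fold higher number from compound 1 to compound 3 (0.33 log units; beyond the scatter) and so shows a modest move toward weaker inhibition at that other place. Open, as far as these compounds go, are the true size of the step from compound 2 and how a methoxy group or an amine would read at the 3,4-dichlorophenyl position.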